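Bicyclic Amine Replaces Cyclopentyl(methyl)amino on the Sulfonamide

The source may report more compounds than this note shows. Statements on the series, on what has been measured and on what is new or still open speak of the compounds shown alone.

Of the compounds shown here, three sharing one core have been measured in an assay on isolated protein for activation of Nicotinamide phosphoribosyltransferase (Homo sapiens); on this read-out higher numbers stand for an effect only at larger amounts of compound and lower numbers for an effect already at smaller amounts. Compound 1 `CCN(C1CCCC1)S(=O)(=O)c1ccc(NC(=O)NCc2ccncc2)cc1` gives 60 nM, compound 2 `O=C(NCc1ccncc1)Nc1ccc(S(=O)(=O)NCc2ccccc2)cc1` gives 102 nM, and compound 3 `CN(C1CCCC1)S(=O)(=O)c1ccc(NC(=O)NCc2ccncc2)cc1` gives 123 nM. Compound 3 carries the highest of the three numbers, though its nearest neighbour compound 2 sits within the scatter of it, and only compound 1 is clearly separated, shown by a 2.1-fold higher number from compound 1 to compound 3 (0.31 log units; beyond the scatter).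

Compound 4 `O=C(NCc1ccncc1)Nc1ccc(S(=O)(=O)N2CC3CCC(C2)O3)cc1` is not yet measured. It differs from compound 3 by a group of 8 heavy atoms (6 carbon, 1 nitrogen, 1 oxygen; one five-membered non-aromatic ring with 1 hetero atom, one six-membered non-aromatic ring with 2 hetero atoms) in place of a group of 7 heavy atoms (6 carbon, 1 nitrogen; one five-membered non-aromatic ring of carbon only), on a sulfonyl sulfur.

Two measured steps change the same position, the group on the sulfonyl sulfur: a 1.7-fold higher number from compound 1 to compound 2 (0.23 log units; within the scatter) and a 1.2-fold higher number from compound 2 to compound 3 (0.08 log units; within the scatter), both within the scatter. Swapping a cyclopentyl(methyl)amino for a benzylamino or a cyclopentyl(ethyl)amino therefore moved this assay little. On these data alone, the incoming bicyclic group with its single acceptor is untested, so the outcome of a 1.0-fold lower number from compound 3 to compound 4 (0.01 log units; within the scatter) is expected to stay within the scatter, with no clear direction. Compound 4 is estimated at 120 nM, ranging from 50 nM to 300 nM.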

Compound 4, half-maximal effective concentration: 279 nM
Estimate against measurement, compound 4: 2.3-fold (0.37 log units) below; the range from low to high includes it.
By their numbers in this assay, from the lowest: compounds 1, 2 and 3 (each within the scatter of the next, the first and the last beyond it); then compound 4.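

Compound 4 shows that the group on the sulfonyl sulfur can shift the number clearly, and upward, meaning that a larger amount of compound is needed for the effect: there is a 2.3-fold higher number from compound 3 to compound 4 (0.36 log units; beyond the scatter) and also a 2.7-fold higher number from compound 2 to compound 4 (0.44 log units; beyond the scatter) and finally a 4.7-fold higher number from compound 1 to compound 4 (0.67 log units; beyond the scatter) on the same scale. All three steps lie beyond the scatter, so compound 4 stands apart from every earlier compound, whereas among those only compound 1 and compound 3 were separated. No measurement shown bears on why the number rose.

On these data alone, it remains open whether the oxygen or the two-ring frame matters more. A morpholine, with its oxygen in a single ring, and a piperidine, with carbon and the nitrogen only, placed on the sulfonyl sulfur would help to separate the two.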